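A few compounds are considered here, and "the series" means these few. Any claim that something is new, unique, unknown or untested is made for them only; others in the source may bear on it.

Of the compounds shown here, two sharing one core have been measured so far in a functional assay on K562 cells (Homo sapiens) for cytotoxicity, read by trypan blue exclusion, with a stated time of 96 h (on this read-out lower numbers stand for stronger inhibition and higher numbers for weaker inhibition), and they give a first reference point. Compound 1 `COC(=O)C(Nc1cc(CS(=O)(=O)/C=C/c2c(OC)cc(OC)cc2OC)ccc1OC)c1ccc(Cl)cc1` carries a (4-chlorophenyl)(methoxycarbonyl)methyl group on its nitrogen and gives 200 nM as its result. Compound 2 `COc1cc(OC)c(/C=C/S(=O)(=O)Cc2ccc(OC)c(NC(C(=O)O)c3ccc(F)cc3)c2)c(OC)c1` carries carboxy(4-fluorophenyl)methyl there instead and gives 80 nM as the lower of the two numbers. Among the compounds with values here, the only measured step is a 2.5-fold lower number from compound 1 to compound 2 (0.40 log units; beyond the scatter) and it is modest. It alters the carboxy end and the halogen together, so the data do not show what the halogen contributes alone.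

Compound 3 `COc1cc(OC)c(/C=C/S(=O)(=O)Cc2ccc(OC)c(NC(C(=O)O)c3ccc(Cl)cc3)c2)c(OC)c1` makes one change to compound 2 (chloro in place of fluoro on an aromatic carbon) with chloro in place of fluoro on an aromatic carbon. Within the data shown here, no measured pair isolates this swap. Compound 3 keeps the carboxy group of compound 2 at 80 nM so a nearby number is expected, with no step beyond the scatter in this assay anticipated. The expected change is a 1.3-fold higher number from compound 2 to compound 3 (0.10 log units; within the scatter) and it remains an estimate. For compound 3 the estimated value is 100 nM with an expected range from 40 nM to 250 nM around it.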

Compound 3, half-maximal inhibitory concentration: 250 nM
Estimate against measurement, compound 3: 2.5-fold (0.40 log units) below; the measured number falls inside the stated range.
By their numbers in this assay, from the lowest: compound 2; then compounds 1 and 3 (each within the scatter of the next).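

Keeping the carboxy group fixed and changing only the halogen gives a 3.1-fold higher number from compound 2 to compound 3 (0.49 log units; beyond the scatter) in this assay, so this aromatic carbon, para to a large group, is sensitive to the swap of fluoro for chloro, which the earlier step could not show because it changed two places at once. With the 4-chlorophenyl group held constant, hydrogen in place of methyl on an oxygen next to a carbonyl group gives a 1.3-fold higher number from compound 1 to compound 3 (0.10 log units; within the scatter), so the methyl ester and the free acid cannot be told apart in this pair, and among these three compounds only the halogen swap gives a step beyond the scatter. Nothing available explains why fluoro and chloro differ here.

As far as these compounds go, it remains open how a hydrogen, a bromo or a methoxy group on that aromatic carbon would compare with fluoro and chloro, and whether the same halogen swap would matter with the methyl ester in place. Also open, from the compounds shown here alone, is whether a primary amide or an ethyl ester at the carboxy end would match the acid in the 4-chlorophenyl series.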